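Halogen Swap on the Amide Aryl of Compound 2

The compounds below may be only part of what the source reports. "The series", "measured", "known", "first", "only" and "open" are said of these compounds alone.

Compound 2 `CCOC(=O)C1=Cc2ccccc2OC1(OCc1cn(CC(=O)Nc2ccccc2Br)nn1)C(F)(F)F` reaches only a limit in a functional assay on A549 cells (Homo sapiens) for inhibition, read by MTT assay, with a stated time of 24 h (on this read-out lower numbers stand for stronger inhibition and higher numbers for weaker inhibition), giving > 150000 nM. Compound 1 `CCOC(=O)C1=Cc2ccccc2OC1(OCc1cc(-c2ccc(OC)cc2)no1)C(F)(F)F` likewise stops at a limit, giving > 150000 nM in this assay. Among the compounds with values here, compound 3 `CCOC(=O)C1=Cc2ccccc2OC1(OCc1cc(-c2cccc(C(F)(F)F)c2)no1)C(F)(F)F` is the one compound with a real number, giving 48600 nM in this assay. Within the data shown here, the sole measured step, an at least 3.0-fold lower number from compound 1 to compound 3 (0.48 log units; beyond the scatter), concerns a different part of the shared core, so it says nothing direct about the change at hand.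

Compound 4 `CCOC(=O)C1=Cc2ccccc2OC1(OCc1cn(CC(=O)Nc2ccc(I)cc2Cl)nn1)C(F)(F)F` differs from compound 2 in one place: 2-chloro-4-iodophenyl in place of 2-bromophenyl on an amide-type nitrogen. Among the measured compounds shown here, no measured step touches this amide-type nitrogen, and the values gathered so far cluster at the limit of > 150000 nM in this assay, at which 2 of the 3 values shown sit. With nothing pointing to a gain, the expectation for compound 4 is a value close to where compound 2 stands, and the expected step is a number no higher from compound 2 to compound 4 (the limit leaves the size open), which is not beyond the scatter. Compound 4 is therefore estimated at 150000 nM, with a range from 50000 nM to 400000 nM, and a limit rather than a number remains the likely report.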

Compound 4, half-maximal inhibitory concentration: 22300 nM
Estimate against measurement, compound 4: 6.7-fold (0.83 log units) above, and the stated range ends above it.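

In this assay, the amide aryl proves to be a position that responds to change: replacing 2-bromophenyl with 2-chloro-4-iodophenyl gives an at least 6.7-fold lower number from compound 2 to compound 4 (0.82 log units; beyond the scatter). On these data alone, compound 2 gives only a limit, so the true size of this step stays unknown, but compound 4 shows that this amide side chain can carry a measurable value. The result also stands apart from the values that stop at the limit: the limit of > 150000 nM in this assay, at which 2 of the 4 values shown sit.

This single change swaps bromine for chlorine and adds iodine, and the compounds shown cannot separate the contribution of each halogen. Placing an amine or a carboxylic acid where the iodine sits would show whether a halogen is required there or whether other groups give a similar step.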